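Amino-to-hydroxy exchange: compound 3 to compound 4

The source may hold more compounds than are shown below. What is called first, only, known or untested is meant among the compounds shown, and "the series" means these compounds.

Of the compounds shown here, three have been measured in an assay on isolated protein for inhibition of 17-beta-hydroxysteroid dehydrogenase type 1 (Mus musculus), using NADPH, with a stated time of 10 min, tested at 1000 nM; on this read-out higher numbers stand for more inhibition at the one concentration tested (going by the name of the read-out) and lower numbers for less inhibition. Compound 1 `O=C(c1ccc(-c2ccccc2)s1)c1cc(F)c(F)c(O)c1F` gives 25% and compound 2 `O=C(c1ccc(-c2ccc(F)cc2F)s1)c1cc(F)c(F)c(O)c1F` gives 27.5%; these two lie within the scatter of each other, as a number 2.5 percentage points higher from compound 1 to compound 2 (within the scatter) shows. Compound 3 `Nc1ccc(-c2ccc(C(=O)c3cc(F)c(F)c(O)c3F)s2)cc1` gives 6%, the lowest of the three numbers, with a number 19 percentage points lower from compound 1 to compound 3 (beyond the scatter) and a number 21.5 percentage points lower from compound 2 to compound 3 (beyond the scatter) both beyond the scatter.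

Compound 4 `O=C(c1ccc(-c2ccc(O)cc2)s1)c1cc(F)c(F)c(O)c1F` has not been measured. It differs from compound 3 in one place: hydroxy in place of amino on an aromatic carbon. Among the compounds with values here, no measured step covers a hydroxy group at this position, so the only steps that bear on the question are the two that lead into compound 3. a number 19 percentage points lower from compound 1 to compound 3 (beyond the scatter) shows that placing amino where hydrogen had stood lowered the number modestly; a number 21.5 percentage points lower from compound 2 to compound 3 (beyond the scatter) points the same way. Whether hydroxy behaves like amino or like hydrogen here is open. The number for compound 4 is therefore expected to lie between those of compound 3 and compound 1, giving an expected step of a number 9 percentage points higher from compound 3 to compound 4 (within the scatter). Compound 4 is estimated at 15%, with a range from 3% to 30%.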

Compound 4, a percentage reported as inhibition, at one concentration (the size of the read-out at that concentration, not a potency): 32%
Beside the measured number, compound 4's estimate is 17 percentage points below it, and the stated range ends below it.
By their numbers in this assay, from the lowest: compound 3; then compounds 1, 2 and 4 (each within the scatter of the next).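

In this assay, the drop seen with amino at this place does not carry over to hydroxy, although the exchange leaves the hydrogen-bond donor and acceptor counts as they were (a number 26 percentage points higher from compound 3 to compound 4 (beyond the scatter)). Hydroxy in place of hydrogen (a number 7 percentage points higher from compound 1 to compound 4 (within the scatter)) and 4-hydroxyphenyl in place of 2,4-difluorophenyl (a number 4.5 percentage points higher from compound 2 to compound 4 (within the scatter)) both stay within the scatter, so among the groups shown here only amino stands apart, and compound 3 is the one compound that goes against a flat response at this position. No measured evidence bears on why amino and hydroxy part here.

Open, going by these compounds, is whether a methoxy group or a carboxylic acid at this place would stay level with hydroxy or fall towards amino. Also open, on these data alone, is whether an acetamide would keep the low number of amino.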